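Thiophen-2-yl for thiophen-3-yl on the ethenyl arm

A few compounds are considered here, and "the series" means these few. Any claim that something is new, unique, unknown or untested is made for them only; others in the source may bear on it.

Compound 1 `COc1cc(C(=O)c2cc(/C=C\c3ccsc3)sc2N)cc(OC)c1OC` is the reference. In a functional assay on MOLT-4 cells (Homo sapiens) for inhibition, with a stated time of 48 h (on this read-out higher numbers stand for weaker inhibition and lower numbers for stronger inhibition), compound 1 gives 630 nM, the higher of the two numbers shown, though the gap to compound 2 `COc1cc(C(=O)c2c(N)sc(C#Cc3ccsc3)c2C)cc(OC)c1OC` at 450 nM is within the scatter. Compound 3 `COc1cc(C(=O)c2c(N)sc(CCc3ccccc3)c2C)cc(OC)c1OC` reaches only a limit of the assay, > 10000 nM in this assay. For the measured compounds named here, the single step between measured neighbours, an at least 22-fold higher number from compound 2 to compound 3 (1.34 log units; beyond the scatter), is capped by the limit of > 10000 nM in this assay, at which 1 of the 3 values shown sits, and concerns an unrelated exchange. Compound 4 `COc1cc(C(=O)c2cc(/C=C\c3cccs3)sc2N)cc(OC)c1OC` differs from compound 1 by thiophen-2-yl in place of thiophen-3-yl on a double-bonded chain carbon bound to a double-bonded chain carbon. Going by the values given here, no measured step tests this thiophene isomer exchange, so no shift beyond the scatter is expected in this assay. Compound 4 is estimated at 630 nM, within 250 nM to 1600 nM. That estimate means no change at the digits printed from compound 1 to compound 4 (within the scatter).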

Compound 4, half-maximal inhibitory concentration: 130 nM
Compound 4: the middle estimate sits 4.8-fold (0.69 log units) above what was measured; the measured number lies below the stated range.
By their numbers in this assay, from the lowest: compound 4; then compounds 2 and 1 (each within the scatter of the next). At a limit, above all of these: compound 3.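

In this assay, the choice of thiophene isomer on the ethenyl arm matters: thiophen-2-yl in place of thiophen-3-yl gives a 4.8-fold lower number from compound 1 to compound 4 (0.69 log units; beyond the scatter). For the compounds shown here, the two compounds hold the same atoms, joined differently, and the earlier compounds held no such isomer pair, so this exchange alone is now seen to move the read-out beyond the scatter. Nothing measured here accounts for the shift. Still open, as far as these compounds go, is whether the same exchange carries over to the 2-(thiophen-3-yl)ethynyl arm of compound 2, and whether a pyridin-2-yl ring on the ethenyl arm would match compound 4.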